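Hydroxy to Methoxy: an Expected Potency Shift

The compounds below may be only part of what the source reports. "The series", "measured", "known", "first", "only" and "open" are said of these compounds alone.

Measured compounds:
compound 1 `CC(C)c1onc(-c2c(Cl)cccc2Cl)c1COc1ccc(-c2ccc3c(C(=O)O)ccnc3c2)cc1`: 560 nM
compound 2 `CC(C)c1onc(-c2c(Cl)cccc2Cl)c1COc1ccc(-c2ccc3c(C(=O)O)nccc3c2)cc1`: 190 nM
compound 3 `CC(C)c1onc(-c2c(Cl)cccc2Cl)c1COc1ccc(-c2ccc3nc(C(=O)O)cc(O)c3c2)cc1`: 10000 nM

In a functional assay on CV-1 cells for agonist activity at Bile acid receptor (Homo sapiens), read by a luciferase reporter (a lower number here means that less compound is needed, a higher number that more compound is needed for the effect), compound 3 carries the highest number of the three, meaning the most compound is needed for the effect. Its nearest neighbour, compound 1, sits well below it, beyond the usual scatter, and compound 2 lies further still, also beyond the scatter. Compound 4 `COc1cc(C(=O)O)nc2ccc(-c3ccc(OCc4c(-c5c(Cl)cccc5Cl)noc4C(C)C)cc3)cc12` is the next step: methyl in place of hydrogen on an oxygen on an aromatic ring. Going by the values given here, no pair of measured compounds shows this particular change, so its effect is unknown. The step is therefore expected to be modest, roughly a 1.7-fold lower number from compound 3 to compound 4 (0.22 log units; within the scatter), with a slight tilt toward a lower number rather than none at all. For compound 4 an estimate of about 6000 nM is expected, with a plausible range from 1500 nM to 25000 nM.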

Compound 4, half-maximal effective concentration: 17 nM
Estimate against measurement, compound 4: 350-fold (2.55 log units) above; measured number outside the range, below it.
By their numbers in this assay, from the lowest: compound 4; then compound 2; then compound 1; then compound 3.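

In this assay, replacing hydroxy with methoxy on this aromatic ring gives a 590-fold lower number from compound 3 to compound 4 (2.77 log units; beyond the scatter) and so shows that a single added methyl on this oxygen can change the amount of compound needed enormously. The earlier compounds shown here, none differing from another in one place only, could not show this. No available evidence explains why the step is so large. On these data alone, whether an ethoxy group or an amine at this place would do as well stays open. So does whether this change would have a similar effect on another core.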